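The compounds below may be only part of what the source reports. "The series", "measured", "known", "first", "only" and "open" are said of these compounds alone.

Compound 3, `Cc1nnsc1CO/N=C/c1c(C)nn(C)c1Oc1ccc(I)cc1`, stands in a functional assay on Huh-7 cells (Homo sapiens) for inhibition, read by MTT assay, with a stated time of 48 h (on this read-out higher numbers stand for weaker inhibition and lower numbers for stronger inhibition), at > 50000 nM, which is a limit of the assay and not a number. Compound 1, `Cc1nnsc1CO/N=C/c1c(C)nn(C)c1Oc1ccccc1Cl`, gives in this assay > 50000 nM, again a limit. Compound 2, `Cc1nnsc1CO/N=C/c1c(C)nn(C)c1Oc1cccc(C(F)(F)F)c1`, gives in this assay > 50000 nM, also a limit. Thus all three measured values sit at the limit of > 50000 nM in this assay, at which 3 of the 3 values shown sit, and the one step among them, a step that the two limits leave unreadable from compound 1 to compound 3, cannot be read because both of its ends are limits. Compound 4, `Cc1cccc(Oc2c(/C=N/OCc3snnc3C)c(C)nn2C)c1`, differs from compound 3 by 3-methylphenyl in place of 4-iodophenyl on an oxygen on an aromatic ring. Among the compounds with values here, no measured step bears readably on this change, since the only comparable step, from compound 1 to compound 3, is hidden by the limits. With no measured movement to point to in either direction, the expectation for compound 4 is that it remains at the limit as well, and the step that the limit leaves unreadable from compound 3 to compound 4 is accordingly expected to be unreadable. Compound 4 is therefore estimated at 80000 nM in this assay, with a range from 20000 nM to 400000 nM.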

Compound 4, half-maximal inhibitory concentration: > 50000 nM
Compound 4 was reported as a limit; the forecaster's own chance of this, stated with the estimate: 85%; the middle value is on the limit's open side.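

Compound 4 joins compound 1, compound 2 and compound 3 at the limit, so no step between compound 4 and any of them can be read: the limit of > 50000 nM in this assay, at which 4 of the 4 values shown sit.

The compounds shown leave open whether these phenyl groups on the oxygen differ from one another at all in this assay.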